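The source may report more compounds than this note shows. Statements on the series, on what has been measured and on what is new or still open speak of the compounds shown alone.

Three compounds were examined in a functional assay on ID8 cells (Mus musculus) for antiproliferative activity (a higher number here means a weaker inhibitor, a lower number a stronger inhibitor), with these results:

- compound 1 `O=C(Nc1ccc(O)c2c(=O)cc(-c3ccccc3Cl)oc12)c1ccc(Cl)c(Cl)c1` gives 13000 nM
- compound 2 `Cc1ccc(C(=O)Nc2ccc(O)c3c(=O)cc(-c4ccccc4Cl)oc23)cc1` gives 16000 nM
- compound 3 `Cc1ccc(C(=O)Nc2c(O)cc(O)c3c(=O)cc(-c4ccccc4Cl)oc23)cc1` gives "not determined" (no result reported)

Going by the values given here, compound 2 at 16000 nM and compound 1 at 13000 nM are the only two numbers available, and they lie within the scatter of each other. Compound 3 has no number.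

The next compound to consider is compound 4 `CCC(C)OC(=O)Nc1ccc(O)c2c(=O)cc(-c3ccccc3Cl)oc12`, reached from compound 2 by the change (sec-butoxy in place of 4-methylphenyl on a carbonyl carbon), which is sec-butoxy in place of 4-methylphenyl on a carbonyl carbon. Among the compounds with values here, only one measured step bears on that carbonyl carbon, namely a 1.2-fold higher number from compound 1 to compound 2 (0.09 log units; within the scatter), and it stays within the scatter. That step exchanges 3,4-dichlorophenyl for 4-methylphenyl, so a ring is present on both sides of it. Within the data shown here, no measured compound carries a group without a ring at this place.

Resting on a 1.2-fold higher number from compound 1 to compound 2 (0.09 log units; within the scatter) alone, no step beyond the scatter is expected in this assay in either direction, although one pair is thin support and the range has to stay wide. The expected change is a 1.1-fold lower number from compound 2 to compound 4 (0.06 log units; within the scatter), which is an estimate only. For compound 4 the estimated value is 14000 nM, with an expected range from 5000 nM to 40000 nM as its limits.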

Compound 4, half-maximal inhibitory concentration: 18000 nM
Estimate against measurement, compound 4: 1.3-fold (0.11 log units) below, and the stated range covers the measured number.
By their numbers in this assay, from the lowest: compounds 1, 2 and 4 (each within the scatter of the next).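

In this assay the carbonyl carbon on the amide-type nitrogen now carries a group with no ring, and this exchange of 4-methylphenyl for sec-butoxy, with its 5 heavy atoms and 1 hydrogen-bond acceptor, gives a step that stays within the scatter (a 1.1-fold higher number from compound 2 to compound 4 (0.05 log units; within the scatter)). Measured against the other ring-bearing group, 3,4-dichlorophenyl, the exchange also stays within the scatter (a 1.4-fold higher number from compound 1 to compound 4 (0.14 log units; within the scatter)), so among these three compounds the aromatic ring at this place can be lost without a step beyond the scatter, which the two ring-bearing compounds alone could not show. Nothing available explains why the three groups sit so close together.

The compounds shown leave open whether any group on this carbonyl carbon can move the number beyond the scatter, for instance an amine, a carboxylic acid or a longer chain such as n-octyloxy. Going by these compounds alone, they also leave open whether sec-butoxy would behave the same way on a core that differs from the one shared by compound 1, compound 2 and compound 4.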